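Adding an Enol Hydroxy to a Dienone Amine Oxidase Inhibitor

The source may hold more compounds than are shown below. What is called first, only, known or untested is meant among the compounds shown, and "the series" means these compounds.

Measured compounds:
- compound 1, `O=C(/C=C(O)/C=C/c1ccc([N+](=O)[O-])cc1)c1ccccc1O`, 2670 nM
- compound 2, `Cc1ccc(/C=C/C(O)=C/C(=O)c2ccccc2O)cc1`, 3770 nM
- compound 3, `O=C(/C=C/C=C/c1ccccc1)c1ccccc1O`, 106 nM

In an in vitro assay on cells for inhibition of Amine oxidase [flavin-containing] B (Homo sapiens), read by Amplex Red, with a stated time of 15 min (on this read-out lower numbers stand for stronger inhibition and higher numbers for weaker inhibition), compound 3 gives the lowest of the three numbers, standing well apart from compound 1 and further still from compound 2, both gaps beyond the scatter. Compound 4, `O=C(/C=C(O)/C=C/c1ccccc1)c1ccccc1O`, differs from compound 3 by hydroxy in place of hydrogen on a double-bonded chain carbon bound to two double-bonded chain carbons; the chain and both rings stay as they are.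

Going by the values given here, only one step is measured, a 1.4-fold higher number from compound 1 to compound 2 (0.15 log units; within the scatter), and it concerns a swap on an aromatic ring, not the chain, so it says nothing directly about the change to compound 4. What the values do show is that compound 1 and compound 2, which both carry this hydroxy, sit far above compound 3, which lacks it, and that the ring substituent they also carry hardly matters. A move toward their region is therefore expected, and the step of a 19-fold higher number from compound 3 to compound 4 (1.28 log units; beyond the scatter) is the estimate that follows. Compound 4 is expected to give about 2000 nM in this assay, within 400 nM to 8000 nM.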

Compound 4, half-maximal inhibitory concentration: 1160 nM
The estimate for compound 4 lay 1.7-fold (0.24 log units) above the measured number, within the range that was stated.
By their numbers in this assay, from the lowest: compound 3; then compound 4; then compounds 1 and 2 (each within the scatter of the next).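

Measured in this assay, the hydroxy can now be read on its own, free of any ring change, and this single swap on the chain carbon gives a large step (an 11-fold higher number from compound 3 to compound 4 (1.04 log units; beyond the scatter)). The ring substituents also turn out to count once the unsubstituted ring is available, though both steps are modest next to the hydroxy step (a 3.3-fold lower number from compound 2 to compound 4 (0.51 log units; beyond the scatter); a 2.3-fold lower number from compound 1 to compound 4 (0.36 log units; beyond the scatter)). Nothing given here explains why the hydroxy or either ring substituent has this effect.

The compounds shown leave open whether a methoxy group or an amine on the same chain carbon would raise the number as the hydroxy does. They also leave open whether methyl or nitro on the aromatic ring would shift the number in the same way in compound 3, which lacks the hydroxy.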